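The source may report more compounds than this note shows. Statements on the series, on what has been measured and on what is new or still open speak of the compounds shown alone.

Four compounds built on one shared core are compared here. Compound 1 `COC(=O)[C@@]1(C)CCC=C2[C@@H]1CC[C@@H](C)[C@]2(C)Cc1c[nH]c2c(Br)cccc12` and compound 2 `COC(=O)[C@@]1(C)CCC=C2[C@@H]1CC[C@@H](C)[C@]2(C)Cc1c[nH]c2c(Cl)cccc12` carry a single substituent on the indole part, and in a functional assay on A549 cells (Homo sapiens) for inhibition, read by sulforhodamine B assay, with a stated time of 48 h (on this read-out higher numbers stand for weaker inhibition of growth and lower numbers for stronger inhibition of growth), compound 1 gives 22000 nM while compound 2 gives 22000 nM. The difference between them is chloro in place of bromo on an aromatic carbon, and the step of no change at the digits printed from compound 1 to compound 2 (within the scatter) shows that this swap left the growth inhibition essentially where it was.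

Compound 3 `COC(=O)[C@@]1(C)CCC=C2[C@@H]1CC[C@@H](C)[C@]2(C)Cc1c(C)[nH]c2ccc(Br)cc12` differs from compound 1 in more than one place; how the two cores differ is not broken down here. In this assay compound 3 gives 15000 nM, a number that lies within the usual scatter of both compound 1 and compound 2, so no order among the three can be read from these values.

Compound 4 `COC(=O)[C@@]1(C)CCC=C2[C@@H]1CC[C@@H](C)[C@]2(C)Cc1c(C)[nH]c2ccc(Cl)cc12` has not yet been measured. It differs from compound 3 by chloro in place of bromo on an aromatic carbon. This is the same kind of change as that from compound 1 to compound 2, though the surroundings of the place are not identical: in the earlier pair the carbon is ortho to a fused ring and meta to a fused ring, whereas here it is meta to a fused ring and para to a fused ring. For the measured compounds named here, since the only comparable swap produced no change at the digits printed from compound 1 to compound 2 (within the scatter), the step from compound 3 to compound 4 in this assay is expected to be about no change at the digits printed from compound 3 to compound 4 (within the scatter). Compound 4 is therefore estimated at 15000 nM, with a likely range from 7000 nM to 32000 nM.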

Compound 4, concentration for 50% growth inhibition: 17000 nM
Estimate against measurement, compound 4: 1.1-fold (0.05 log units) below; the range from low to high includes it.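

On the core of compound 3, chloro in place of bromo gives in this assay a step of a 1.1-fold higher number from compound 3 to compound 4 (0.05 log units; within the scatter), so here too the swap leaves growth inhibition essentially where it was. Set beside the earlier pair, this means the absence of an effect carries over from one core to the other, even though the swapped carbon has different surroundings in the two pairs: the same change on two cores in this assay, no change at the digits printed (within the scatter) from compound 1 to compound 2 and a 1.1-fold higher number (0.05 log units; within the scatter) from compound 3 to compound 4, 1.1-fold (0.05 log units) apart, within the scatter of two such steps.
For the compounds shown here, this agreement rests on only two pairs, and it concerns a swap that produced no readable change on either core, so it does not show that a change with a real effect would carry over in the same way, nor that this swap would behave alike on other cores or in other assays.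

Both pairs exchange one halogen for another, so they say nothing about how a clearly different group at these places, such as a fluoro, a methoxy, a nitrile or an amine, would affect growth inhibition. Also open, on these data alone, is whether any change elsewhere on the shared core, for example a carboxylic acid in place of the methyl ester, would shift the values beyond the usual scatter.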